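Estimating compound 4 from three weakly cytotoxic relatives

The source may hold more compounds than are shown below. What is called first, only, known or untested is meant among the compounds shown, and "the series" means these compounds.

Compound 1 `COc1ccc(Nc2nc(-c3cccc(F)c3)nc3ccc(F)cc23)cc1` gives 32300 nM in a functional assay on U2OS cells (Homo sapiens) for cytotoxicity, read by MTT assay, with a stated time of 48 h; a lower number here means a stronger inhibitor, a higher number a weaker inhibitor.
Compound 2 `COc1ccccc1Nc1nc(-c2cccc(F)c2)nc2ccc(F)cc12` gives only a limit of the assay, > 50000 nM.
Compound 3 `Fc1cccc(Nc2nc(-c3cccc(F)c3)nc3ccc(F)cc23)c1` gives 49600 nM.

Where compound 3 stands: of the two numbers shown it is separated from compound 1 by a 1.5-fold higher number from compound 1 to compound 3 (0.19 log units; within the scatter), and the value of compound 2 is a limit, as the line the limit of > 50000 nM in this assay, at which 1 of the 3 values shown sits, records. The change to compound 4 `Fc1cccc(-c2nc(Nc3ccc(Cl)cc3)c3cc(F)ccc3n2)c1` is 4-chlorophenyl in place of 3-fluorophenyl on a nitrogen on an aromatic ring. Going by the values given here, the steps that bear on it all exchange the group on that nitrogen: an at least 1.5-fold higher number from compound 1 to compound 2 (0.18 log units; that floor lies within the scatter), a 1.5-fold higher number from compound 1 to compound 3 (0.19 log units; within the scatter) and a number no higher from compound 2 to compound 3 (the limit leaves the size open), none resolved beyond the scatter. Compound 4 is therefore expected to show no step beyond the scatter, a 1.2-fold lower number from compound 3 to compound 4 (0.09 log units; within the scatter), with an estimate of 40000 nM spanning 15000 nM to 90000 nM.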

Compound 4, half-maximal inhibitory concentration: 38400 nM
The estimate for compound 4 lay 1.0-fold (0.02 log units) above the measured number; low and high end bracket the measured number.
By their numbers in this assay, from the lowest: compounds 1, 4 and 3 (each within the scatter of the next). At a limit, above all of these: compound 2.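

In this assay, 4-chlorophenyl on this nitrogen does not separate from the groups already seen there: a 1.3-fold lower number from compound 3 to compound 4 (0.11 log units; within the scatter), and, with chloro in place of methoxy on an aromatic carbon, a 1.2-fold higher number from compound 1 to compound 4 (0.08 log units; within the scatter). Compound 2 remains a limit of the assay, so only a floor can be read for its step, an at least 1.3-fold lower number from compound 2 to compound 4 (0.11 log units; that floor lies within the scatter), and this too resolves nothing: the limit of > 50000 nM in this assay, at which 1 of the 4 values shown sits. Halogen or methoxy, at either printed ring position, the phenyl groups here give one flat picture.

The compounds shown leave open whether anything other than a substituted phenyl on this nitrogen, such as a piperidine or a benzyl group, would step beyond the scatter in this assay. They also leave open what a carboxylic acid or an amine on that phenyl ring would do.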